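From 2,3-dimethoxyphenyl to 2-methoxyphenyl in compound 4

This account rests on a few compounds, and the source may have more. Where it says the series, first, only, none or still open, it means among the compounds named here.

- Compound 1 `O=C1C(=Cc2ccc(Br)cc2)C(=O)N(c2ccc(Cl)cc2)N1c1ccc(Cl)cc1`: 16600 nM
- Compound 2 `COc1ccc(C=C2C(=O)N(c3ccc(Cl)cc3)N(c3ccc(Cl)cc3)C2=O)cc1`: > 128000 nM (a limit, not a number)
- Compound 3 `COc1cccc(C=C2C(=O)N(c3ccc(Cl)cc3)N(c3ccc(Cl)cc3)C2=O)c1OC`: 14100 nM

In a functional assay on SMMC-7721 cells (Homo sapiens) for cytotoxicity, read by MTT assay, with a stated time of 72 h (on this read-out lower numbers stand for stronger inhibition and higher numbers for weaker inhibition), compound 3 sits level with compound 1, with a 1.2-fold lower number from compound 1 to compound 3 (0.07 log units; within the scatter). Compound 2 is reported only as a limit, (the limit of > 128000 nM in this assay, at which 1 of the 3 values shown sits). Compound 4 `COc1ccccc1C=C1C(=O)N(c2ccc(Cl)cc2)N(c2ccc(Cl)cc2)C1=O` has hydrogen in place of methoxy on an aromatic carbon, ortho to a methoxy group (hydrogen in place of methoxy on an aromatic carbon). For the measured compounds named here, no measured step makes this exact change. The closest guide is the exchange of 4-methoxyphenyl for 2,3-dimethoxyphenyl, an at least 9.0-fold lower number from compound 2 to compound 3 (0.95 log units; beyond the scatter), which lies beyond the scatter. Losing a methoxy from compound 3 should therefore raise the number modestly, though compound 2 differs in where its methoxy sits. The expected change is a 2.8-fold higher number from compound 3 to compound 4 (0.45 log units; beyond the scatter). For compound 4 the estimate is 40000 nM, within an expected range of 12000 nM to 128000 nM.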

Compound 4, half-maximal inhibitory concentration: 25800 nM
Estimate against measurement, compound 4: 1.6-fold (0.19 log units) above; the measured number falls inside the stated range.
By their numbers in this assay, from the lowest: compounds 3, 1 and 4 (each within the scatter of the next). At a limit, above all of these: compound 2.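

In this assay, hydrogen in place of the methoxy ortho to a methoxy group gives a 1.8-fold higher number from compound 3 to compound 4 (0.26 log units; within the scatter), and the 4-bromophenyl comparison gives a 1.6-fold higher number from compound 1 to compound 4 (0.19 log units; within the scatter), both within the scatter, so the second methoxy is not needed to stay in this range. Where the single methoxy sits does separate the two monomethoxy compounds, with an at least 4.9-fold lower number from compound 2 to compound 4 (0.69 log units; beyond the scatter). That step rests on a limit, not a number: the limit of > 128000 nM in this assay, at which 1 of the 4 values shown sits.

As far as these compounds go, it remains open whether an amine or a hydroxyl in place of this methoxy would keep the number in this range. From the compounds shown here alone, whether ethoxy would do so is also open.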